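The source may report more compounds than this note shows. Statements on the series, on what has been measured and on what is new or still open speak of the compounds shown alone.

Going by the values given here, in a toxicity assay on HEK-293T cells (Homo sapiens) for cytotoxicity, read by MTT assay, with a stated time of 72 h (on this read-out higher numbers stand for weaker inhibition and lower numbers for stronger inhibition), compound 2 `O=C1c2c[n+]([O-])c3ccccc3c2C(=O)c2c1c1ccccc1n2Cc1cn(C[C@H](O)CO)nn1` gives 8880 nM, the higher of the two numbers so far, while compound 1 `O=C1c2c[n+]([O-])c3ccccc3c2C(=O)c2c1c1ccccc1n2Cc1cn([C@@H]2C[C@H](O)[C@@H](CO)O2)nn1` gives 820 nM. Compound 3 `CC1(C)OCC(Cn2cc(Cn3c4c(c5ccccc53)C(=O)c3c[n+]([O-])c5ccccc5c3C4=O)nn2)O1` keeps the shared core but changes one group: 2,2-dimethyl-1,3-dioxolan-4-yl in place of 1,2-dihydroxyethyl on a saturated chain carbon bound to an aromatic nitrogen. Its two hydroxyl-bearing carbons become part of a new ring. Among the compounds with values here, the only measured step that bears on this, an 11-fold higher number from compound 1 to compound 2 (1.03 log units; beyond the scatter), was large and removed a ring from the group on an aromatic nitrogen, though it is a loose guide. A smaller move towards stronger inhibition is therefore expected in this assay, a 3.0-fold lower number from compound 2 to compound 3 (0.47 log units; beyond the scatter). For compound 3 the estimate is 3000 nM, with an expected range of 900 nM to 10000 nM.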

Compound 3, half-maximal inhibitory concentration: 5510 nM
Beside the measured number, compound 3's estimate is 1.8-fold (0.26 log units) below it, and the stated range covers the measured number.
By their numbers in this assay, from the lowest: compound 1; then compounds 3 and 2 (each within the scatter of the next).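

In this assay, tying the two hydroxyl groups of 1,2-dihydroxyethyl into 2,2-dimethyl-1,3-dioxolan-4-yl gives a 1.6-fold lower number from compound 2 to compound 3 (0.21 log units; within the scatter), so this larger, ring-bearing group with no hydrogen-bond donors cannot be told apart from the open group. A ring alone does not bring back the lower number: (2,2-dimethyl-1,3-dioxolan-4-yl)methyl in place of 4-hydroxy-5-(hydroxymethyl)oxolan-2-yl gives a 6.7-fold higher number from compound 1 to compound 3 (0.83 log units; beyond the scatter). No available evidence accounts for either step. The compounds shown leave open whether an amine or a longer chain at this place would move the number beyond the scatter.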